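Ethoxy to methoxy: working notes on the series

The compounds below may be only part of what the source reports. "The series", "measured", "known", "first", "only" and "open" are said of these compounds alone.

Measured so far:
compound 1, `O=C(Nc1ccccc1Cl)c1ccc(C(=O)O)nc1`: 16300 nM
compound 2, `CCOc1ccccc1NC(=O)c1ccc(C(=O)O)nc1`: 32900 nM

In an assay on isolated protein (Gallus gallus) for inhibition of transmembrane prolyl 4-hydroxylase (Homo sapiens) (on this read-out lower numbers stand for stronger inhibition and higher numbers for weaker inhibition), compound 1 gives 16300 nM and compound 2 gives 32900 nM. Within the data shown here, compound 2 therefore stands with the higher of the two numbers, and the single step so far, a 2.0-fold higher number from compound 1 to compound 2 (0.31 log units; beyond the scatter), is the only measured change to the substituent on the aromatic carbon of the anilide ring.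

Compound 3, `COc1ccccc1NC(=O)c1ccc(C(=O)O)nc1`, differs from compound 2 by hydrogen in place of methyl on a saturated chain carbon bound to an oxygen on an aromatic ring; cut one bond further out this reads ethyl to methyl, ethoxy to methoxy. Among the measured compounds shown here, no measured step shortens a chain on this oxygen. For the measured compounds named here, the one step that touches this part of the molecule, a 2.0-fold higher number from compound 1 to compound 2 (0.31 log units; beyond the scatter), exchanges the whole group and was modest; trimming one carbon from the chain while keeping the oxygen is a smaller change than that. The step expected in this assay for this change is a 1.3-fold lower number from compound 2 to compound 3 (0.10 log units; within the scatter), within the scatter, leaning if anything toward compound 1. Compound 3 is accordingly expected to give 26000 nM, with a range of 12000 nM to 55000 nM.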

Compound 3, half-maximal inhibitory concentration: 14800 nM
Compound 3: middle estimate off by 1.8-fold (0.24 log units), on the high side; measured number inside the range.
By their numbers in this assay, from the lowest: compounds 3 and 1 (each within the scatter of the next); then compound 2.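

In this assay, among these compounds, the change from ethoxy to methoxy is the first measured shortening of a chain on this oxygen, and one carbon is enough to give a step beyond the scatter (a 2.2-fold lower number from compound 2 to compound 3 (0.35 log units; beyond the scatter)). That step is rated modest, as is the exchange of the whole group (a 2.0-fold higher number from compound 1 to compound 2 (0.31 log units; beyond the scatter)), so trimming the chain does not read as the smaller change here. The step from chloro to methoxy stays within the scatter (a 1.1-fold lower number from compound 1 to compound 3 (0.04 log units; within the scatter)), so among these three compounds the higher number goes with ethoxy alone, not with an oxygen on the aromatic carbon as such, and no measurement explains why this one carbon shifts the number.

With only methoxy and ethoxy on this oxygen, two points do not establish a trend with chain length, and a longer chain such as propoxy or a branched one such as isopropoxy could either extend the rise or break it. Also open, as far as these compounds go, is how a hydroxyl or an amine in place of methoxy would compare with the chloro of compound 1, and whether hydrogen there would give a number of the same order.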